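The compounds below may be only part of what the source reports. "The series", "measured", "known", "first", "only" and "open" are said of these compounds alone.

In a toxicity assay on THP-1 cells (Homo sapiens) for inhibition (on this read-out higher numbers stand for lower toxicity in this test and lower numbers for higher toxicity in this test), compound 1 `Cc1cccc(-c2cnc(NC(=O)c3ccc(F)cc3)n2C)c1` gives > 100000 nM, which is a limit and not a number. Compound 2 `Cn1c(-c2cccc(C#N)c2)cnc1NC(=O)c1ccc(F)cc1` gives > 100000 nM, which is again a limit. Compound 3 `COc1ccccc1-c1cnc(NC(=O)c2ccc(F)cc2)n1C`, the starting point of this account, gives > 100000 nM, and this too is only a limit. For the measured compounds named here, compound 3 therefore has no exact place among the three, and the whole series so far comes down to the limit of > 100000 nM in this assay, at which 3 of the 3 values shown sit.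

Compound 4 `Cn1c(-c2cccc(F)c2)cnc1NC(=O)c1ccc(F)cc1` arises from compound 3 by a single change, 3-fluorophenyl in place of 2-methoxyphenyl on an aromatic carbon. Going by the values given here, three measured steps bear on this change: a step that the two limits leave unreadable from compound 1 to compound 2, a step that the two limits leave unreadable from compound 1 to compound 3 and a step that the two limits leave unreadable from compound 2 to compound 3. None of them has a readable size, and none of the swaps among 3-methylphenyl, 3-cyanophenyl and 2-methoxyphenyl produced a number in this assay.

Since compound 3 shares the limit of > 100000 nM in this assay, at which 3 of the 3 values shown sit, with compound 1 and compound 2, no step beyond the scatter is expected for this change, in either direction. The expected outcome is a number no higher from compound 3 to compound 4 (the limit leaves the size open). Compound 4 is estimated at 100000 nM, with an expected range of 50000 nM to 200000 nM, and it will most likely be reported only as a limit.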

Compound 4, half-maximal cytotoxic concentration: 58000 nM
Compound 4: middle estimate off by 1.7-fold (0.24 log units), on the high side; the range from low to high includes it.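

With 3-fluorophenyl on this aromatic carbon, this assay returns a number rather than a limit, which none of the earlier swaps at this place had done: the limit of > 100000 nM in this assay, at which 3 of the 4 values shown sit. The change from the 2-methoxyphenyl compound gives an at least 1.7-fold lower number from compound 3 to compound 4 (0.23 log units; that floor lies within the scatter), and the two changes on the phenyl group, fluoro for cyano and fluoro for methyl, give an at least 1.7-fold lower number from compound 2 to compound 4 (0.23 log units; that floor lies within the scatter) and an at least 1.7-fold lower number from compound 1 to compound 4 (0.23 log units; that floor lies within the scatter). Each of these steps is only a floor, since one end of it is a limit, so the result shows that this place can bring the read-out into the measurable range, but it does not establish a step beyond the scatter.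

On these data alone, how large the true steps are stays open, as the other three compounds have no exact values. Also open, as far as these compounds go, is whether another group on this phenyl ring, such as an amine, a carboxylic acid or a longer chain, would give a number in this assay, and whether 2-fluorophenyl would behave as 3-fluorophenyl does.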